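Three Limits and an Untested Fluorophenyl Analogue

This account rests on a few compounds, and the source may have more. Where it says the series, first, only, none or still open, it means among the compounds named here.

Measured in an ADME assay on Raji cells (Homo sapiens) for cytotoxicity, read by CellTiter-Glo and resazurin assay, with a stated time of 72 h; on this read-out lower numbers stand for an effect already at smaller amounts and higher numbers for an effect only at larger amounts of compound:
- compound 1 `CCOC(=O)CCCCCOc1cccc(CN(C(=O)c2ccc(-c3cccc(NC(C)=O)c3)cc2)C(C)C)c1` gives > 26000 nM
- compound 2 `CCOC(=O)CCCCCOc1cccc(CN(C(=O)c2ccc(-c3cccc(O)c3)cc2)C(C)C)c1` gives > 26000 nM
- compound 3 `CCOC(=O)CCCCCOc1cccc(CN(C(=O)c2ccc(-c3cc(OC)ccc3F)cc2)C(C)C)c1` gives > 26000 nM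

Each of these three values is a limit of the assay, not a number. The value of compound 1 is such a limit. The value of compound 2 is such a limit. The value of compound 3 is such a limit as well. Accordingly the steps a step that the two limits leave unreadable from compound 1 to compound 2, a step that the two limits leave unreadable from compound 1 to compound 3 and a step that the two limits leave unreadable from compound 2 to compound 3 cannot be read, and compound 3 stands with the other two at the same boundary (the limit of > 26000 nM in this assay, at which 3 of the 3 values shown sit).

Compound 4 `CCOC(=O)CCCCCOc1cccc(CN(C(=O)c2ccc(-c3cccc(F)c3)cc2)C(C)C)c1` is the next member. The change is 3-fluorophenyl in place of 2-fluoro-5-methoxyphenyl on an aromatic carbon. Going by the values given here, the steps that bear on it, a step that the two limits leave unreadable from compound 2 to compound 3 and a step that the two limits leave unreadable from compound 1 to compound 3, were both unreadable, so no size or direction can be drawn from them. Compound 4 is therefore expected to sit at the limit too, with an expected step that the limit leaves unreadable from compound 3 to compound 4 in this assay. The estimate for compound 4 is 40000 nM, within a range from 15000 nM to 120000 nM.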

Compound 4, half-maximal effective concentration: > 26000 nM
Compound 4 ended at the assay's limit (the forecaster's own chance of this, stated with the estimate: 80%); the middle value does not contradict the limit.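

Going by these compounds alone, no step between compound 4 and compound 1, compound 2 or compound 3 can be read, because all four values are limits of the assay, not numbers: the limit of > 26000 nM in this assay, at which 4 of the 4 values shown sit. The compounds shown leave open whether the groups exchanged on the shared core differ at all in this assay.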